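The source may hold more compounds than are shown below. What is called first, only, known or untested is meant among the compounds shown, and "the series" means these compounds.

- Compound 1 `CCOc1cc(C(C)(C)C)ccc1C1=NC(c2ccc(Cl)cc2)C(c2ccc(Cl)cc2)N1C(=O)NCCCCCCCC(=O)Nc1ccccc1N`: 19600 nM
- Compound 2 `CCOc1cc(C(C)(C)C)ccc1C1=NC(c2ccc(Cl)cc2)C(c2ccc(Cl)cc2)N1C(=O)N1CCN(CCCCCC(=O)NO)CC1`: 9390 nM

In a functional assay on NCI-H1299 cells (Homo sapiens) for antiproliferative activity, read by CCK-8 assay, with a stated time of 72 h (a higher number here means a weaker inhibitor, a lower number a stronger inhibitor), compound 1 gives 19600 nM and compound 2 gives 9390 nM as the lower of the two numbers. That margin lies just beyond the usual scatter. Compound 3 `CCOc1cc(C(C)(C)C)ccc1C1=NC(c2ccc(Cl)cc2)C(c2ccc(Cl)cc2)N1C(=O)N1CCN(c2ncc(C(=O)NO)cn2)CC1` carries 5-(hydroxycarbamoyl)pyrimidin-2-yl in place of the 5-(hydroxycarbamoyl)pentyl of compound 2, on an amine nitrogen in a ring: 5-(hydroxycarbamoyl)pyrimidin-2-yl in place of 5-(hydroxycarbamoyl)pentyl on an amine nitrogen in a ring. Going by the values given here, no measured pair shows an exchange of this kind, so any expectation in this assay rests on only two compounds and remains loose. The estimated step of a 1.6-fold lower number from compound 2 to compound 3 (0.19 log units; within the scatter) is expected to be modest, towards a lower number, and it may not clear the scatter. The estimate for compound 3 is 6000 nM, with an expected range from 1500 nM to 25000 nM.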

Compound 3, half-maximal inhibitory concentration: 5450 nM
Compound 3: middle estimate off by 1.1-fold (0.04 log units), on the high side, and the stated range covers the measured number.
By their numbers in this assay, from the lowest: compounds 3 and 2 (each within the scatter of the next); then compound 1.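

In this assay, 5-(hydroxycarbamoyl)pyrimidin-2-yl in place of 5-(hydroxycarbamoyl)pentyl on the amine nitrogen in the ring gives a 1.7-fold lower number from compound 2 to compound 3 (0.24 log units; within the scatter). So at this position, a six-membered aromatic ring with 2 hetero atoms can take the place of an open chain, and the two compounds cannot be told apart in this read-out. No measurement shown offers an explanation for this result.

The compounds leave open whether the hydroxycarbamoyl group itself is needed here, which a carboxylic acid or a primary amide at the same place would test. As far as these compounds go, it also remains open how a longer chain or a phenyl ring bearing hydroxycarbamoyl on this nitrogen would read in this assay.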